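From piperidin-1-yl to 4-methylpiperidin-1-yl at the assay limit

The compounds below may be only part of what the source reports. "The series", "measured", "known", "first", "only" and "open" are said of these compounds alone.

Compound 1 `CCN(CC)CCCOc1cc2ncnc(Nc3nc4ccc(C(=O)Nc5c(C)cccc5C)cc4s3)c2cc1OC` and compound 2 `COc1cc2c(Nc3nc4ccc(C(=O)Nc5c(C)cccc5C)cc4s3)ncnc2cc1OCCCN1CCCCC1` share a core and differ in their amine group. In a functional assay on HCT-116 cells (Homo sapiens) for cytotoxicity, read by WST assay, with a stated time of 72 h (a lower number here means a stronger inhibitor, a higher number a weaker inhibitor), compound 1 gives > 100000 nM as a limit of the assay and not a number. In this assay compound 2 gives > 100000 nM as a limit too. For the measured compounds named here, compound 2 therefore has no numerical standing, and the one other value is also a limit. Compound 3 `COc1cc2c(Nc3nc4ccc(C(=O)Nc5c(C)cccc5C)cc4s3)ncnc2cc1OCCCN1CCC(C)CC1` has methyl in place of hydrogen on a saturated ring carbon of compound 2 (methyl in place of hydrogen on a saturated ring carbon). Going by the values given here, only one measured step bears on this change, a step that the two limits leave unreadable from compound 1 to compound 2 and its size cannot be read. The expectation rests on the limit of > 100000 nM in this assay, at which 2 of the 2 values shown sit, and gives no direction. The estimated step in this assay is a number no higher from compound 2 to compound 3 (the limit leaves the size open) and lies within the scatter. Compound 3 is expected at about 100000 nM within an estimated range of 40000 nM to 250000 nM and will probably be reported as a limit again.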

Compound 3, half-maximal inhibitory concentration: > 100000 nM
Compound 3 ended at the assay's limit; the forecaster's own chance of this, stated with the estimate: 80%; the middle value sits exactly at the limit.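

No step can be read among compound 1, compound 2 and compound 3 in this assay and their amine groups cannot be ranked: the limit of > 100000 nM in this assay, at which 3 of the 3 values shown sit. The compounds shown leave open whether any change to the amine group would give a value readable as a number.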